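The source may report more compounds than this note shows. Statements on the series, on what has been measured and on what is new or still open speak of the compounds shown alone.

In a functional assay on A2780 cells (Homo sapiens) for antiproliferative activity, read by CellTiter-Glo, with a stated time of 72 h (on this read-out lower numbers stand for stronger inhibition and higher numbers for weaker inhibition), compound 1 `O=C(Nc1ccc(CN2Cc3ccccc3C2=O)cc1)N1CC(c2cccnc2)C1` gives 0.6 nM and compound 2 `C[C@@H](c1ccc(NC(=O)N2CC(c3cccnc3)C2)cc1)N1Cc2ccccc2C1=O` gives 1.5 nM, the higher of the two numbers. Compound 3 `CCC(=O)N[C@@H](C)c1ccc(NC(=O)N2CC(c3cccnc3)C2)cc1` brings in propanoylamino on a saturated chain carbon: a group of 5 heavy atoms (3 carbon, 1 nitrogen, 1 oxygen; no ring) in place of a group of 10 heavy atoms (8 carbon, 1 nitrogen, 1 oxygen; one five-membered non-aromatic ring with 1 hetero atom, one six-membered aromatic ring of carbon only), on a saturated chain carbon bound to an aromatic carbon and a saturated chain carbon. For the measured compounds named here, the only measured step, a 2.5-fold higher number from compound 1 to compound 2 (0.40 log units; beyond the scatter), placed a methyl on that same carbon and left the larger group untouched, so it is a loose guide. Going by the values given here, no measured compound varies this group itself. A moderate rise is expected, larger than that step, and the expected change is a 4.0-fold higher number from compound 2 to compound 3 (0.60 log units; beyond the scatter). For compound 3 the estimate is 6 nM, with an expected range of 1.5 nM to 30 nM.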

Compound 3, half-maximal inhibitory concentration: 25 nM
Beside the measured number, compound 3's estimate is 4.2-fold (0.62 log units) below it, and the stated range covers the measured number.
By their numbers in this assay, from the lowest: compound 1; then compound 2; then compound 3.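

For the compounds shown here, replacing the larger group on this saturated chain carbon with propanoylamino gives a 17-fold higher number from compound 2 to compound 3 (1.22 log units; beyond the scatter) in this assay and is the first measured change to the group itself. This large step shows that the number responds much more strongly to this exchange than to the methyl added in a 2.5-fold higher number from compound 1 to compound 2 (0.40 log units; beyond the scatter) on the same carbon. No evidence here explains the rise.

The exchange removes both rings and adds a hydrogen-bond donor, so the effect of each remains unseparated. On these data alone, how a benzoylamino group or a simple amine on this carbon would read also remains open.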